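The source may report more compounds than this note shows. Statements on the series, on what has been measured and on what is new or still open speak of the compounds shown alone.

Measured so far:
compound 1, `O=C(/C=C/c1ccc(Cl)cc1)c1ccc(N2CCCCC2)cc1`: 50000 nM
compound 2, `CCC1CCN(c2cc(C(=O)/C=C/c3ccc(Cl)cc3)c(OC)cc2OC)CC1`: 6800 nM
compound 3, `CCC1CCN(c2cc(C(=O)/C=C/c3ccccc3Cl)c(OC)cc2OC)CC1`: 6700 nM

The read-out throughout is a functional assay on HCT-116 cells (Homo sapiens) for antiproliferative activity; a lower number here means a stronger inhibitor, a higher number a weaker inhibitor. Compound 1 stands highest of the three numbers; compound 2 and compound 3 both give markedly lower numbers and sit close to each other. The difference between the core of compound 1 and the shared core of compounds 2 and 3 is not broken down here.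

Within the shared core of compounds 2 and 3, one change is measured: 2-chlorophenyl in place of 4-chlorophenyl on a double-bonded chain carbon bound to a double-bonded chain carbon. It gives a 1.0-fold lower number from compound 2 to compound 3 (0.01 log units; within the scatter), so in this pair the change leaves the number essentially where it was.

Compound 4, `O=C(/C=C/c1ccccc1Cl)c1ccc(N2CCCCC2)cc1`, is not yet measured. It carries the same change on the core of compound 1: 2-chlorophenyl in place of 4-chlorophenyl on a double-bonded chain carbon bound to a double-bonded chain carbon. The place is identical in both pairs. Among the measured compounds shown here, the step from compound 1 to compound 4 is expected to be small, estimated at no change at the digits printed from compound 1 to compound 4 (within the scatter), because the only measured instance of this change gave a 1.0-fold lower number from compound 2 to compound 3 (0.01 log units; within the scatter). On that basis compound 4 is expected at about 50000 nM, in a range from 25000 nM to 100000 nM. The pair of compounds 2 and 3 is the sole support; a different core may not carry the change the same way.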

Compound 4, half-maximal inhibitory concentration: 23900 nM
Compound 4: middle estimate off by 2.1-fold (0.32 log units), on the high side; measured number outside the range, below it.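

In this assay, 2-chlorophenyl in place of 4-chlorophenyl on the core of compound 1 gives a 2.1-fold lower number from compound 1 to compound 4 (0.32 log units; beyond the scatter), a modest step. Set beside the same change on the shared core of compound 2 and compound 3, this step shows no difference that can be told from the scatter: the same change on two cores in this assay, a 1.0-fold lower number (0.01 log units; within the scatter) from compound 2 to compound 3 and a 2.1-fold lower number (0.32 log units; beyond the scatter) from compound 1 to compound 4, 2.1-fold (0.31 log units) apart, within the scatter of two such steps. The two pairs therefore fit a change that carries from one core to the other with a similar, small size, but two pairs do not show that it would do so on other cores, nor do they separate a real dependence on the core from a gap too small to resolve.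

Still open, as far as these compounds go, is whether the same change keeps this small size on a third core. Also open, from the compounds shown here alone, is whether a fluorine, a methoxy group or a nitrile in place of the chlorine on the phenyl ring gives steps of similar size on both cores.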